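Ring amine substituent variation on the shared core

The source may hold more compounds than are shown below. What is called first, only, known or untested is meant among the compounds shown, and "the series" means these compounds.

Measured compounds:
compound 1 `CCCn1c(=O)[nH]c2nc(-c3ccc(S(=O)(=O)N4CCN(c5ccc(F)cc5)CC4)cc3)[nH]c2c1=O` — 0.644 nM
compound 2 `CCCn1c(=O)[nH]c2nc(-c3ccc(S(=O)(=O)N4CCN(Cc5cccc(C)c5)CC4)cc3)[nH]c2c1=O` — 0.397 nM
compound 3 `CCCn1c(=O)[nH]c2nc(-c3ccc(S(=O)(=O)N(C)C)cc3)[nH]c2c1=O` — 18.6 nM

Compound 2 gives the lowest number of the three in an assay on CHO cells for displacement of a labelled ligand from adenosine receptor A2b (Homo sapiens), read by scintillation counting, with a stated time of 75 min, in the presence of a further agent that is not named here; a lower number here means a stronger inhibitor, a higher number a weaker inhibitor. Its nearest neighbour is compound 1; the step of a 1.6-fold lower number from compound 1 to compound 2 (0.21 log units; within the scatter) lies within the scatter, so no order between compound 1 and compound 2 is claimed. Compound 3, which carries two methyl groups on the nitrogen in place of the ring amine with its aromatic substituent, gives a far higher number.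

Compound 4 `CCCn1c(=O)[nH]c2nc(-c3ccc(S(=O)(=O)N4CCN(C)CC4)cc3)[nH]c2c1=O` differs from compound 2 by hydrogen in place of 3-methylphenyl on a saturated chain carbon bound to an amine nitrogen in a ring. Going by the values given here, no measured step covers this exact change. Among the compounds with values here, the one measured step, a 1.6-fold lower number from compound 1 to compound 2 (0.21 log units; within the scatter), exchanges one aromatic group for another and is within the scatter, so it says little about removing the aromatic group altogether. The values of compound 2 and compound 3 show that losing the ring amine together with its aromatic substituent goes with a much higher number. Compound 4 keeps the ring amine but loses the aromatic group, so a step toward higher numbers is expected, smaller than the gap to compound 3. Compound 4 is expected to give 5 nM, with a range from 1.5 nM to 20 nM. The expected step is a 13-fold higher number from compound 2 to compound 4 (1.10 log units; beyond the scatter).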

Compound 4, inhibition constant: 48.2 nM
Compound 4: the middle estimate sits 9.6-fold (0.98 log units) below what was measured, outside the stated range (above it).
By their numbers in this assay, from the lowest: compounds 2 and 1 (each within the scatter of the next); then compound 3; then compound 4.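

In this assay, cutting 3-methylbenzyl back to methyl on the ring amine gives a 120-fold higher number from compound 2 to compound 4 (2.08 log units; beyond the scatter), and methyl in place of 4-fluorophenyl gives a 75-fold higher number from compound 1 to compound 4 (1.87 log units; beyond the scatter). Both steps are large, which the exchange of one aromatic group for the other could not show. The ring amine alone brings no gain: 4-methylpiperazin-1-yl in place of dimethylamino on a sulfonyl sulfur gives a 2.6-fold higher number from compound 3 to compound 4 (0.41 log units; beyond the scatter), so among these compounds the low numbers go with the aromatic group on the ring amine, not with the ring itself. Nothing on hand gives a cause for these steps.

Going by these compounds, whether an ethyl or cyclohexylmethyl group on the same nitrogen would keep the low numbers stays open. So does the outcome of a carboxylic acid on the aromatic ring of the 3-methylbenzyl group.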